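The source may hold more compounds than are shown below. What is called first, only, known or untested is meant among the compounds shown, and "the series" means these compounds.

Of the compounds shown here, three have so far been tested in an ADME assay on MT4 cells (Homo sapiens) for cytotoxicity, read by MTT assay, with a stated time of 96 h; a lower number here means that less compound is tolerated, a higher number that more compound is tolerated: compound 1 `Fc1ccc(-c2nc3cc(C(F)(F)F)ccc3[nH]2)cc1`, compound 2 `O=C(CN1CCCCC1)Nc1ccc(-c2nc3cc(Cl)c(Cl)cc3[nH]2)cc1` and compound 3 `COc1ccc(-c2nc3cc([N+](=O)[O-])ccc3[nH]2)c(OC)c1`. In this assay compound 1 gives 22000 nM and compound 2 gives 54000 nM. For compound 3 the result is a limit of the assay rather than a number, > 100000 nM. The line the limit of > 100000 nM in this assay, at which 1 of the 3 values shown sits, marks the point at which that value sits. Among the two compounds with actual numbers, compound 2 stands highest, meaning it is tolerated up to the larger concentration of the two, and its distance from compound 1 lies beyond the scatter that repeated measurements of this kind usually show.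

Compound 4 `Nc1ccc(-c2nc3cc(Cl)c(Cl)cc3[nH]2)cc1` has not yet been measured. It differs from compound 2 in one place: hydrogen in place of ((piperidin-1-yl)methyl)carbonyl on a nitrogen on an aromatic ring. For the measured compounds named here, no pair among the measured compounds differs in a way that matches this change, so there is no measured step to lean on. The change simply removes that group from compound 2 and leaves a molecule with fewer atoms. With nothing measured to point to, a modest move is expected and no direction beyond the scatter can be claimed; the step of a 1.4-fold lower number from compound 2 to compound 4 (0.13 log units; within the scatter) expresses this expectation. Compound 4 is therefore estimated at 40000 nM, most likely between 15000 nM and 100000 nM.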

Compound 4, half-maximal cytotoxic concentration: 17000 nM
Compound 4: middle estimate off by 2.4-fold (0.37 log units), on the high side; the range from low to high includes it.
By their numbers in this assay, from the lowest: compounds 4 and 1 (each within the scatter of the next); then compound 2. At a limit, above all of these: compound 3.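

For the compounds shown here, removing the ((piperidin-1-yl)methyl)carbonyl group from the nitrogen on the aromatic ring and leaving hydrogen gives a 3.2-fold lower number from compound 2 to compound 4 (0.50 log units; beyond the scatter) in this assay, the first step in this set that isolates a single change. Going by these compounds alone, at this position, therefore, the compound carrying the group is tolerated up to a higher concentration than the bare amine, a direction that the earlier compounds could not show, since no two of them differed in only one place. The data shown offer no measurement that explains this shift.

From the compounds shown here alone, it remains open whether the whole group or only part of it goes with the higher number: an acetyl group on the same nitrogen would keep the carbonyl without the piperidine ring, while a morpholine ring in place of the piperidine would test the ring itself. This is also a single pair on one core, and it cannot yet be said whether the same change would give a similar step on a different core.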